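A few compounds are considered here, and "the series" means these few. Any claim that something is new, unique, unknown or untested is made for them only; others in the source may bear on it.

Series notes. Going by the values given here, the fragment compound 1 `O=Cc1cccc(OCc2cn(Cc3ccccc3)nn2)c1` and the condensed product compound 2 `O=C1Nc2ccc(C(c3ccccc3)c3ccccc3)cc2/C1=C\c1cccc(OCc2cn(Cc3ccccc3)nn2)c1` are the two members measured so far in a functional assay on A549 cells (Homo sapiens) for inhibition, read by MTT assay, with a stated time of 48 h; a lower number here means a stronger inhibitor, a higher number a weaker inhibitor. In this assay compound 1 reports only a limit, > 50000 nM. In this assay compound 2 likewise reports only a limit, > 50000 nM. Compound 2 therefore stands at the upper edge of the numbers shown, at the limit of > 50000 nM in this assay, at which 2 of the 2 values shown sit; no numerical value fixes it. Compound 3 `O=C1Nc2ccc(C(c3ccccc3)c3ccccc3)cc2/C1=C/c1cccc(OCc2cn(Cc3ccccc3)nn2)c1` is the next member to be tested. It differs from compound 2 in drawn configuration only: the two compounds have the same atoms and bonds and differ only in configuration as drawn: 1 of 1 stereo elements differ; a double bond is drawn E in compound 2 and Z in compound 3. Among the compounds with values here, no step between measured compounds exists to size the effect of such a change. Because compound 2 sits at the limit of > 50000 nM in this assay, at which 2 of the 2 values shown sit, the step from compound 2 to compound 3 is expected at a step that the limit leaves unreadable from compound 2 to compound 3, none beyond the scatter. Compound 3 is estimated at 60000 nM in this assay, between 15000 nM and 200000 nM.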

Compound 3, half-maximal inhibitory concentration: 14700 nM
Estimate against measurement, compound 3: 4.1-fold (0.61 log units) above; the whole stated range lies above it.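

Going by these compounds alone, the drawn configuration of the double bond is the first change to give a readable difference: in this assay the data show an at least 3.4-fold lower number from compound 2 to compound 3 (0.53 log units; beyond the scatter). The lower number can be assigned to the configuration alone, because no atom or bond changes: the fact that compounds 2 and 3 differ only in the configuration as drawn. The true size of the step remains unfixed and only its lower bound is known, because compound 2 carries a limit rather than a number: the limit of > 50000 nM in this assay, at which 2 of the 3 values shown sit.

This configuration effect rests on a single pair, so it is not yet known whether it holds across the series. On these data alone, it also remains open whether compound 3 would keep or improve its value in this assay with a carboxylic acid or a dimethylamino group on the shared core, and whether the double-bond configuration would then still separate such a pair.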